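The compounds below may be only part of what the source reports. "The series", "measured", "known", "first", "only" and "open" are said of these compounds alone.

Three measured compounds share one core and differ only in the group set on one aromatic carbon. Compound 1 `Brc1cn2ccnc2c(-c2ccc3ncn(C4CCCCC4)c3c2)n1` carries a bromo there; in a functional assay on PC-3 cells (Homo sapiens) for inhibition, read by sulforhodamine B assay, with a stated time of 48 h, tested at 10 uM (on this read-out lower numbers stand for less inhibition and higher numbers for more inhibition at the one concentration tested (going by the name of the read-out)), compound 1 gives 17.2%. Compound 2 `CC(=O)c1ccc(-c2cn3ccnc3c(-c3ccc4ncn(C5CCCCC5)c4c3)n2)cc1` carries a 4-acetylphenyl, and compound 2 gives 17.9%. Compound 3 `Clc1ccc(-c2cn3ccnc3c(-c3ccc4ncn(C5CCCCC5)c4c3)n2)cc1` carries a 4-chlorophenyl, and compound 3 gives 24.6%. Compound 3 thus holds the highest of the three numbers, yet the steps of a number 7.4 percentage points higher from compound 1 to compound 3 (within the scatter) and a number 6.7 percentage points higher from compound 2 to compound 3 (within the scatter) both lie within the scatter, as does a number 0.7 percentage points higher from compound 1 to compound 2 (within the scatter), so none of the three separates from the others.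

Compound 4 `c1csc(-c2cn3ccnc3c(-c3ccc4ncn(C5CCCCC5)c4c3)n2)c1` differs from compound 3 in one place: thiophen-2-yl in place of 4-chlorophenyl on an aromatic carbon. Every measured step that varied this same position, whether a bromo, a 4-acetylphenyl or a 4-chlorophenyl sat there, stayed within the scatter, so a thiophen-2-yl in this position is expected to behave alike, and the step of a number 4.6 percentage points lower from compound 3 to compound 4 (within the scatter) is expected to stay within the scatter as well. For compound 4 the estimate is 20%, with a range from 8% to 32%.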

Compound 4, a percentage reported as inhibition, at one concentration (the size of the read-out at that concentration, not a potency): 49.1%
Beside the measured number, compound 4's estimate is 29.1 percentage points below it, outside the stated range (above it).
By their numbers in this assay, from the lowest: compounds 1, 2 and 3 (each within the scatter of the next); then compound 4.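

The position is not as indifferent as the first three compounds suggested. In this assay, the thiophen-2-yl stands clear of all three other groups, with a number 24.5 percentage points higher from compound 3 to compound 4 (beyond the scatter), a number 31.2 percentage points higher from compound 2 to compound 4 (beyond the scatter) and a number 31.9 percentage points higher from compound 1 to compound 4 (beyond the scatter), so what sits on this aromatic carbon can change the read-out, at least for this one five-membered aromatic ring with a hetero atom. Nothing available here explains why this group stands apart.

The compounds shown cannot separate the effect of the smaller ring from that of its sulfur, and a furan-2-yl, with oxygen in place of sulfur, or a plain phenyl would help to pull the two apart. On these data alone, whether an amine or a carboxylic acid on this carbon would fit the same picture also stays open.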